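Ether cap on the phenol of compound 3

The source may hold more compounds than are shown below. What is called first, only, known or untested is meant among the compounds shown, and "the series" means these compounds.

The four compounds share one core and one acid-bearing side group. Compound 1 `O=C1COc2cccc(SC3(C(=O)O)CCC3)c2N1` is reported in an assay on HEK293 cells for inhibition of solute carrier family 22 member 12 (Homo sapiens), read by scintillation counting, with a stated time of 12 min (a higher number here means a weaker inhibitor, a lower number a stronger inhibitor), only as the limit > 10000 nM. Within the data shown here, compound 2 `Nc1ccc2nccc(SC3(C(=O)O)CCC3)c2c1`, which carries an amino group, gives 1790 nM in this assay and is the only member with a number rather than a limit. Compound 3 `O=C(O)C1(Sc2ccnc3ccc(O)cc23)CCC1` is reported in this assay only as the limit > 10000 nM. Compound 3 therefore stands at the weak end of what is shown, together with compound 1, and two of the three values sit at the limit of > 10000 nM in this assay, at which 2 of the 3 values shown sit. Among the measured compounds shown here, the one step that can be read, an at least 5.5-fold higher number from compound 2 to compound 3 (0.74 log units; beyond the scatter), shows that the hydroxy compound is at least modestly weaker than the amino compound.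

Compound 4 `COCCOc1ccc2nccc(SC3(C(=O)O)CCC3)c2c1` differs from compound 3 by 2-methoxyethyl in place of hydrogen on an oxygen on an aromatic ring. For the measured compounds named here, no measured step touches the hydroxy hydrogen itself; the step from the amino compound only sets the phenol at or beyond the limit, so the direction of the cap cannot be fixed from the data. Compound 4 is therefore expected near the limit, at 10000 nM with a range from 2000 nM to 50000 nM, and the step of a number no higher from compound 3 to compound 4 (the limit leaves the size open) is expected to be small against the limit, with a fair chance that only a limit is reported again.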

Compound 4, half-maximal inhibitory concentration: 207 nM
Beside the measured number, compound 4's estimate is 48-fold (1.68 log units) above it, and the stated range ends above it.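

Capping the oxygen on the aromatic ring with 2-methoxyethyl gives an at least 48-fold lower number from compound 3 to compound 4 (1.68 log units; beyond the scatter) in this assay, so this place in the series accepts a substituent on that oxygen, and the free hydroxy is not required for inhibition. The 2-methoxyethoxy group also compares well with the amino group on the same aromatic carbon, with an 8.6-fold lower number from compound 2 to compound 4 (0.94 log units; beyond the scatter), so the earlier loss on going from amino to hydroxy does not mean that any oxygen-linked group at this place is weak. The true size of the gain from capping remains open, because compound 3 is held only by a limit: the limit of > 10000 nM in this assay, at which 2 of the 4 values shown sit.

The compounds shown do not separate the effect of capping the oxygen from that of the chain itself, and a simple methoxy, an ethoxy or a longer chain ending in methoxy would be needed to tell these apart. As far as these compounds go, it also remains open whether the terminal methoxy matters, which a chain ending in a hydroxy, an amine or a carboxylic acid would address.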